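Swapping Fluorophenyl for Cyclohexyl on a Shared Core

The source may hold more compounds than are shown below. What is called first, only, known or untested is meant among the compounds shown, and "the series" means these compounds.

Of the compounds shown here, three built on one core have been tested in an ADME assay on Vero cells (Chlorocebus sabaeus) for cytotoxicity, read by MTT assay, with a stated time of 48 h; a lower number here means a stronger inhibitor, a higher number a weaker inhibitor. Compound 1 `O=c1cc(NCc2ccc3c(c2)OCCO3)sc2c([N+](=O)[O-])cc(C(F)(F)F)cc12` reaches only a limit of the assay, > 64 ug/mL. Compound 2 `O=c1cc(NCc2cccc(F)c2)sc2c([N+](=O)[O-])cc(C(F)(F)F)cc12` likewise gives a limit rather than a number, > 64 ug/mL. Compound 3 `COc1ccc(CNc2nc(=O)c3cc(C(F)(F)F)cc([N+](=O)[O-])c3o2)cc1OC` does give a number, 29.2 ug/mL. Going by the values given here, compound 2 therefore stands among the values for which the assay reports no number, and the one measured step that touches it, a step that the two limits leave unreadable from compound 1 to compound 2, has no readable size.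

Compound 4 `O=c1cc(NCC2CCCCC2)sc2c([N+](=O)[O-])cc(C(F)(F)F)cc12` is the next change from compound 2:

cyclohexyl in place of 3-fluorophenyl on a saturated chain carbon bound to a nitrogen on an aromatic ring

No measured step among these compounds involves a cyclohexyl, and the single step adjoining compound 2 cannot be read, so the data set no size and no direction for the change in this assay. What the numbers do show is the limit of > 64 ug/mL in this assay, at which 2 of the 3 values shown sit, and compound 2 is one of the two. Compound 4 is therefore expected to sit at or near that same limit. The step that the limit leaves unreadable from compound 2 to compound 4 is estimated to be none beyond the scatter. For compound 4 the estimate in this assay is 70 ug/mL, with a range from 30 ug/mL to 160 ug/mL.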

Compound 4, half-maximal inhibitory concentration: > 64 ug/mL
Compound 4: no number, only a limit; the forecaster's own chance of this, stated with the estimate: 65%; the middle value is on the limit's open side.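

In this assay compound 4 gives > 64 ug/mL, which is a limit of the assay and not a number. Compound 1 and compound 2 also stop at limits, so neither step to compound 4 can be read. The compounds shown leave open whether cyclohexyl in place of 3-fluorophenyl changes the result in this assay at all.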